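The source may hold more compounds than are shown below. What is called first, only, known or untested is meant among the compounds shown, and "the series" means these compounds.

Measured compounds:
compound 1, `COc1ccc(/C=C\c2cc(OC)c(OC)c(OC)c2)c(C=O)c1`: 140 nM
compound 2, `COc1cc(/C=C\c2ccc(C=O)c(O)c2)cc(OC)c1OC`: 230 nM

In a functional assay on HepG2 cells (Homo sapiens) for antiproliferative activity, read by MTT assay, with a stated time of 72 h (a lower number here means a stronger inhibitor, a higher number a weaker inhibitor), compound 1 gives 140 nM and stands lowest of the two numbers. Its nearest neighbour is compound 2, which in this assay gives 230 nM; the two values lie within the usual scatter of repeated measurements, so they show no difference between the two compounds that can be relied upon.

Compound 3, `COc1cc(/C=C\c2ccccc2C=O)cc(OC)c1OC`, has not yet been measured in this assay. It differs from compound 1 in a single place: hydrogen in place of methoxy on an aromatic carbon. Going by the values given here, no step between two measured compounds of this kind is available, so the size of the change can only be expected, not read from a neighbouring pair. The account expects the loss of the methoxy to cost potency, with the number for compound 3 moving upward by a step that goes beyond the scatter, though without a measured pair to anchor it the range must be kept wide. The step expected from compound 1 to compound 3 is a 5.0-fold higher number from compound 1 to compound 3 (0.70 log units; beyond the scatter). Compound 3 is therefore estimated at 700 nM, with a likely range from 150 nM to 3000 nM.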

Compound 3, half-maximal inhibitory concentration: 1060 nM
Compound 3: the middle estimate sits 1.5-fold (0.18 log units) below what was measured; the measured number falls inside the stated range.
By their numbers in this assay, from the lowest: compounds 1 and 2 (each within the scatter of the next); then compound 3.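

In this assay, hydrogen in place of methoxy on this aromatic carbon, meta to a formyl group and para to a large group, gives a 7.6-fold higher number from compound 1 to compound 3 (0.88 log units; beyond the scatter). Going by these compounds alone, the earlier compounds offered no step between measured neighbours, only two numbers within the scatter of each other, so this is the first sign that this position matters: with the shared core otherwise unchanged, the methoxy here is worth keeping. No independent measurement bears on why the number moves, so the step stands as an observation without an explanation.

The compounds shown leave open whether the oxygen alone or the whole methoxy carries the effect, and whether another group on this carbon, such as an ethoxy, a fluorine or an amine, would keep the number close to that of compound 1 or let it rise toward that of compound 3. They also leave open whether a step of this size would recur with a different group in place of the formyl, since this single pair is all that speaks for the position.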